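This account rests on a few compounds, and the source may have more. Where it says the series, first, only, none or still open, it means among the compounds named here.

Compound 1 `C[C@@H](c1c[nH]c2ncccc12)c1nnc2ccc(-c3cnn(C)c3)nn12`: < 7.6 mL.min-1.g-1 (a limit of the assay, not a number)
Compound 2 `C[C@@H](c1c[nH]c2ncccc12)c1nnc2ccc(-c3ccc(C#N)cc3)nn12`: 28 mL.min-1.g-1
Compound 3 `COc1ccc(-c2ccc3nnc([C@@H](C)c4ccc5ncccc5c4)n3n2)cc1F`: 281 mL.min-1.g-1

All three compounds were tested in an ADME assay on microsomes from liver (Homo sapiens) for metabolic stability, read by LC-MS, with a stated time of 30 min, tested at 1 uM; a higher number here means faster removal of the compound, a lower number slower removal. Compound 3 gives 281 mL.min-1.g-1, the highest of the numbers. The nearest number, from compound 2 at 28 mL.min-1.g-1, is lower by well beyond the usual scatter.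

Compound 4 `C[C@@H](c1ccc2ncccc2c1)c1nnc2ccc(-c3ccccc3C#N)nn12` differs from compound 3 in one place, with 2-cyanophenyl in place of 3-fluoro-4-methoxyphenyl on an aromatic carbon. This exact swap has not been measured. The closest evidence is an at least 3.6-fold higher number from compound 1 to compound 2 (0.56 log units; beyond the scatter), where 4-cyanophenyl replaced another group and the number moved beyond the scatter. On these data alone, that step starts from a limit, though, so its true size is unknown (the limit of < 7.6 mL.min-1.g-1 in this assay, at which 1 of the 3 values shown sits), and it says nothing directly about the group leaving compound 3. Compound 2 also carries a cyanophenyl group and reads 28 mL.min-1.g-1, but it differs from compound 3 in a second place too, so the group cannot be credited with that whole gap. A partial fall is therefore the likeliest outcome, and the expected step is a 2.6-fold lower number from compound 3 to compound 4 (0.41 log units; beyond the scatter), towards slower removal. Compound 4 is estimated at 110 mL.min-1.g-1, with an expected range of 40 mL.min-1.g-1 to 260 mL.min-1.g-1.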

Compound 4, intrinsic clearance in microsomes: 23.1 mL.min-1.g-1
Compound 4: middle estimate off by 4.8-fold (0.68 log units), on the high side, outside the stated range (below it).
By their numbers in this assay, from the lowest: compounds 4 and 2 (each within the scatter of the next); then compound 3. At a limit, below all of these: compound 1.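

In this assay, putting 2-cyanophenyl in place of 3-fluoro-4-methoxyphenyl gives a 12-fold lower number from compound 3 to compound 4 (1.09 log units; beyond the scatter), a large move towards slower removal with the rest of the molecule unchanged. This shows that the group on this aromatic carbon, on the ring with two nitrogens, can by itself decide much of how fast these compounds are cleared. The earlier step at this position, on a different core, started from a limit of the assay and so had no known size, whereas this one joins two real numbers, though nothing measured here explains why the number fell so far.

The swap removes a methoxy group and a fluorine and adds a nitrile in one move, so the compounds shown cannot say which of these changes matters most; a plain phenyl, a 4-methoxyphenyl or a 3-fluorophenyl on the same core would begin to separate them. Also open, on these data alone, is whether the nitrile needs to sit where it does in 2-cyanophenyl, or whether 4-cyanophenyl or 1-methyl-1H-pyrazol-4-yl would serve as well on this core.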